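Acetamido Substitution on Compound 1: An Expectation

The source may hold more compounds than are shown below. What is called first, only, known or untested is meant among the compounds shown, and "the series" means these compounds.

Compound 1 `Cc1nc(-c2ccccc2)c(C(=O)N2CCN(c3cccc(Cl)c3)CC2)o1`: 39.2 nM
Compound 2 `O=C(c1oc(C(F)(F)F)nc1-c1cccc(F)c1)N1CCN(c2cccc(Cl)c2)CC1`: "not active" (no number reported)

Of the compounds shown here, two have been tested in a functional assay on HL-60 cells (Homo sapiens) for inhibition, read by MTT assay, with a stated time of 72 h; a higher number here means a weaker inhibitor, a lower number a stronger inhibitor. Among the measured compounds shown here, compound 1 gives 39.2 nM, which is the only number available, so compound 1 stands alone as the reference point. For the measured compounds named here, compound 2 carries a trifluoromethyl group and a fluorine on the phenyl in place of the methyl of compound 1, and in this assay compound 2 is reported only as "not active" (no number reported), without a number; this leaves no measured step to lean on.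

Compound 3 `CC(=O)Nc1cccc(-c2nc(C)oc2C(=O)N2CCN(c3cccc(Cl)c3)CC2)c1` is the next compound to be tested. Compared with compound 1, the change is acetamido in place of hydrogen on an aromatic carbon. The shared core, the amide and the piperazine bearing the chloro-substituted ring all stay the same; only the phenyl on the core gains an acetamido group, meta to a large group.

Going by the values given here, no measured step with this kind of change exists here, so the expectation rests on compound 1 alone. A modest weakening seems more likely than a gain, but a result within the scatter of compound 1 is also plausible. The step from compound 1 to compound 3 is expected to be a 2.0-fold higher number from compound 1 to compound 3 (0.31 log units; beyond the scatter) in this assay. Compound 3 is therefore estimated at 80 nM, with a range from 15 nM to 400 nM.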

Compound 3, half-maximal inhibitory concentration: 208 nM
Compound 3: middle estimate off by 2.6-fold (0.41 log units), on the low side; low and high end bracket the measured number.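

In this assay, among the compounds shown here, acetamido in place of hydrogen on the phenyl ring, meta to a large group, gives a 5.3-fold higher number from compound 1 to compound 3 (0.72 log units; beyond the scatter) and so provides the first measured step at this position, one that lies beyond the usual scatter. The change weakens inhibition without abolishing it: compound 3 still gives a measurable 208 nM in the same cell assay, so this carbon of the ring can carry the acetamido group at a modest cost in potency. Nothing available here shows why the step goes in this direction or has this size.

With a single substitution at a single place, the compounds shown leave open whether the loss belongs to the acetamido group itself or would come with other groups on this carbon, such as an amine or a carboxylic acid. They also leave open whether the acetamido group would cost more, less or about the same on another carbon of the phenyl ring.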